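From fluoro to bromo on the phenoxy group

A few compounds are considered here, and "the series" means these few. Any claim that something is new, unique, unknown or untested is made for them only; others in the source may bear on it.

In a functional assay for inhibition, with Homo sapiens as the target (a higher number here means weaker binding, a lower number tighter binding), compound 1 `COc1ccc(OC(C)(C)C2OCC(C/C=C\CCC(=O)O)C(c3cccnc3)O2)cc1` gives 302 nM and compound 2 `Cc1ccc(OC(C)(C)C2OCC(C/C=C\CCC(=O)O)C(c3cccnc3)O2)cc1` gives 631 nM while compound 3 `CC(C)(Oc1ccccc1F)C1OCC(C/C=C\CCC(=O)O)C(c2cccnc2)O1` gives 166 nM as a dissociation constant. The step of a 1.8-fold lower number from compound 1 to compound 3 (0.26 log units; within the scatter) lies within the scatter and the step of a 3.8-fold lower number from compound 2 to compound 3 (0.58 log units; beyond the scatter) lies beyond it, so compound 3 stands level with compound 1 and clear of compound 2. Compound 4 `CC(C)(Oc1ccccc1Br)C1OCC(C/C=C\CCC(=O)O)C(c2cccnc2)O1` differs from compound 3 by bromo in place of fluoro on an aromatic carbon as bromo in place of fluoro on an aromatic carbon, ortho to a large group. For the measured compounds named here, no measured step exchanges fluoro for bromo. The closest case, a 2.1-fold higher number from compound 1 to compound 2 (0.32 log units; beyond the scatter) for methyl in place of methoxy on an aromatic carbon, is modest. The expected step of a 1.1-fold lower number from compound 3 to compound 4 (0.04 log units; within the scatter) in this assay therefore stays within the scatter, with no firm direction. Compound 4 is expected at 150 nM within an estimated range of 60 nM to 400 nM overall.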

Compound 4, dissociation constant: 63.1 nM
Compound 4: middle estimate off by 2.4-fold (0.38 log units), on the high side; low and high end bracket the measured number.
By their numbers in this assay, from the lowest: compound 4; then compounds 3 and 1 (each within the scatter of the next); then compound 2.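

In this assay the position ortho to a large group proves sensitive to which halogen it carries, with a 2.6-fold lower number from compound 3 to compound 4 (0.42 log units; beyond the scatter) for bromo in place of fluoro. Compound 3 stood level with compound 1, but the bromo compound separates from both other phenoxy compounds, with a 4.8-fold lower number from compound 1 to compound 4 (0.68 log units; beyond the scatter) and a 10-fold lower number from compound 2 to compound 4 (1.00 log units; beyond the scatter) as the steps, and holds the lowest number of the four. No measurement shown accounts for this gain.

From the compounds shown here alone, whether chloro or iodo would continue the trend from fluoro to bromo remains open, as does the outcome with an amine at this position.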